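This account rests on a few compounds, and the source may have more. Where it says the series, first, only, none or still open, it means among the compounds named here.

Measured compounds in a functional assay on KB cells (Homo sapiens) for inhibition; a higher number here means a weaker inhibitor, a lower number a stronger inhibitor:
Compound 1 `C#CCSc1nc2cc(Cl)c(Cl)cc2n1C1O[C@H](CO)[C@@H](O)[C@H]1O` gives 60000 nM.
Compound 2 `N#CCSc1nc2cc(Cl)c(Cl)cc2n1C1O[C@H](CO)[C@@H](O)[C@H]1O` gives only a limit of the assay, > 100000 nM.
Compound 3 `OC[C@H]1OC(n2c(SCc3ccccc3Cl)nc3cc(Cl)c(Cl)cc32)[C@H](O)[C@@H]1O` gives 30000 nM.

Compound 1 holds the higher of the two numbers; the nearest is compound 3, a 2.0-fold lower number from compound 1 to compound 3 (0.30 log units; within the scatter), a gap within the scatter. The third value is a limit (the limit of > 100000 nM in this assay, at which 1 of the 3 values shown sits).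

Compound 4 `CC(C)(C)c1ccc(CSc2nc3cc(Cl)c(Cl)cc3n2C2O[C@H](CO)[C@@H](O)[C@H]2O)cc1` differs from compound 1 by 4-(tert-butyl)phenyl in place of ethynyl on a saturated chain carbon bound to a sulfur. Among the compounds with values here, the only measured step that bears on this change is the one from compound 1 to compound 3, where a 2-chlorophenyl also replaces the ethynyl: a 2.0-fold lower number from compound 1 to compound 3 (0.30 log units; within the scatter). A step of similar size, toward a lower number, is therefore expected here, with no assurance of moving beyond the scatter. Compound 4 is estimated at 30000 nM, between 10000 nM and 90000 nM, which means an expected step of a 2.0-fold lower number from compound 1 to compound 4 (0.30 log units; within the scatter).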

Compound 4, half-maximal inhibitory concentration: 50000 nM
Estimate against measurement, compound 4: 1.7-fold (0.22 log units) below, and the stated range covers the measured number.
By their numbers in this assay, from the lowest: compounds 3, 4 and 1 (each within the scatter of the next). At a limit, above all of these: compound 2.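

In this assay, the 4-(tert-butyl)phenyl, with its 10 heavy atoms, changes little on a saturated chain carbon bound to a sulfur, whether set against ethynyl (a 1.2-fold lower number from compound 1 to compound 4 (0.08 log units; within the scatter)) or against 2-chlorophenyl (a 1.7-fold higher number from compound 3 to compound 4 (0.22 log units; within the scatter)). Compound 2 gives only a limit of the assay. Against its cyano group the step is therefore only a floor (an at least 2.0-fold lower number from compound 2 to compound 4 (0.30 log units; that floor lies within the scatter)), and no separation beyond the scatter can be claimed for this change.

From the compounds shown here alone, whether an amine, a carboxylic acid or a longer chain at this place would move the number beyond the scatter stays open.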